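Replacing the isopropyl ester with a pyrrolidine amide

A few compounds are considered here, and "the series" means these few. Any claim that something is new, unique, unknown or untested is made for them only; others in the source may bear on it.

Three members of this series have been measured in a functional assay on HEK293 cells for agonist activity at Vasopressin V2 receptor (Homo sapiens), read by a luciferase reporter and cAMP accumulation; a higher number here means that more compound is needed for the effect, a lower number that less compound is needed. Compound 1 `Cc1cc(C(=O)N2CCCCc3ccccc32)ccc1CNC(=O)Nc1c(F)cccc1F` gives 2.1 nM. Compound 2 `COC(=O)CNC(=O)NCc1ccc(C(=O)N2CCCCc3ccccc32)cc1C` gives 37 nM, and compound 3 `Cc1cc(C(=O)N2CCCCc3ccccc32)ccc1CNC(=O)NCC(=O)OC(C)C` gives 140 nM. Compound 3 therefore stands at the highest number of the three: its nearest neighbour is compound 2, with a 3.8-fold higher number from compound 2 to compound 3 (0.58 log units; beyond the scatter), while the wider gap is a 67-fold higher number from compound 1 to compound 3 (1.82 log units; beyond the scatter). The two ester compounds both fall far from compound 1, as an 18-fold higher number from compound 1 to compound 2 (1.25 log units; beyond the scatter) also shows.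

Compound 4 `Cc1cc(C(=O)N2CCCCc3ccccc32)ccc1CNC(=O)NCC(=O)N1CCCC1` is the next step from compound 3. The change is pyrrolidin-1-yl in place of isopropoxy on a carbonyl carbon; cut one bond further out it reads isopropoxycarbonyl to (pyrrolidin-1-yl)carbonyl.

Going by the values given here, no measured step exchanges the oxygen side of this carbonyl for a nitrogen. Among the compounds with values here, the only step that touches the same carbonyl is the one from compound 2 to compound 3, where a change on the oxygen gave a 3.8-fold higher number from compound 2 to compound 3 (0.58 log units; beyond the scatter), a modest effect. The direction for compound 4 is therefore open; a modest step either way, or none beyond the scatter, seems the most that can be expected, with a 1.4-fold lower number from compound 3 to compound 4 (0.15 log units; within the scatter) as the working guess. Compound 4 is accordingly expected to give 100 nM in this assay, within a range of 30 nM to 400 nM.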

Compound 4, half-maximal effective concentration: 100 nM
The estimate for compound 4 equals the measured number at the digits printed; the measured number falls inside the stated range.
By their numbers in this assay, from the lowest: compound 1; then compound 2; then compounds 4 and 3 (each within the scatter of the next).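

In this assay, going by these compounds alone, pyrrolidin-1-yl on the carbonyl carbon gives a 1.4-fold lower number from compound 3 to compound 4 (0.15 log units; within the scatter) when it stands in place of isopropoxy, so the esters no longer mark the only tolerated type of group here, and this ring-bearing amide cannot be told apart from the isopropyl ester of compound 3. The same group in place of methoxy gives a 2.7-fold higher number from compound 2 to compound 4 (0.43 log units; beyond the scatter) and thus leaves the methyl ester of compound 2 as the nearer match to the 2,6-difluorophenyl compound, while ((pyrrolidin-1-yl)carbonyl)methyl in place of 2,6-difluorophenyl on the amide-type nitrogen gives a 48-fold higher number from compound 1 to compound 4 (1.68 log units; beyond the scatter) and shows that an amide on this carbonyl carbon does not close the large gap that the esters opened. No available evidence bears on what lies behind these steps.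

Open, from the compounds shown here alone, is whether a free carboxylic acid, a primary amide or an open-chain dimethylamide on the same carbonyl carbon would stay with compound 3 and compound 4 or move towards compound 2. Also open, going by these compounds, is whether a longer chain before the carbonyl, or a piperidine in place of the pyrrolidine, would shift the number in either direction.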